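Trimming the Alkyne Substituent: Compound 3 to Compound 4

This account rests on a few compounds, and the source may have more. Where it says the series, first, only, none or still open, it means among the compounds named here.

Measured compounds:
- Compound 1 `C/C(C#Cc1ccc(CCC(=O)O)c(F)c1)=C/CO`: 105%
- Compound 2 `C=C(C)C#Cc1ccc(CCC(=O)O)cc1`: 108%
- Compound 3 `C/C=C(/C)C#Cc1ccc(CCC(=O)O)c(F)c1`: 103%

In a functional assay on 1321-N1 cells for agonist activity at Free fatty acid receptor 1 (Homo sapiens), read by calcium flux, with a stated time of 0.4 s (on this read-out lower numbers stand for smaller maximal responses and higher numbers for larger maximal responses), compound 3 gives 103%, the lowest of the three numbers, but both other values lie within the scatter of it. Among the compounds with values here, the only measured step, a number 2 percentage points lower from compound 1 to compound 3 (within the scatter), was also within the scatter. Compound 4 `C=C(C)C#Cc1ccc(CCC(=O)O)c(F)c1` differs from compound 3 by 1-methylethenyl in place of 1-methylprop-1-en-1-yl on a triple-bonded carbon. Within the data shown here, no measured step matches this change; compound 2, which also carries the 1-methylethenyl group, gives 108%. With all three values close together, no step beyond the scatter is expected, so a number 2 percentage points higher from compound 3 to compound 4 (within the scatter) is the estimated change. Compound 4 is therefore expected to give about 105%, between 92% and 118%.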

Compound 4, largest response reached (reported as efficacy), in percent of the reference or control that the assay uses: 106%
The estimate for compound 4 lay 1 percentage points below the measured number; measured number inside the range.
By their numbers in this assay, from the lowest: compounds 3, 1, 4 and 2 (each within the scatter of the next).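

Swapping in 1-methylethenyl on the triple-bonded carbon stays within the scatter in this assay, both against 1-methylprop-1-en-1-yl (a number 3 percentage points higher from compound 3 to compound 4 (within the scatter)) and against 3-hydroxy-1-methylprop-1-en-1-yl (a number 1 percentage points higher from compound 1 to compound 4 (within the scatter)), so the maximal response tolerates a smaller group here and does not depend on the hydroxy group. Fluoro in place of hydrogen on an aromatic carbon now has a matched step of its own, also within the scatter (a number 2 percentage points lower from compound 2 to compound 4 (within the scatter)). No evidence is available to explain these results.

From the compounds shown here alone, whether an amine or a longer chain on the triple-bonded carbon would keep this response remains open.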